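Fluoro Gives Way to Chloro on the Shared Core

A few compounds are considered here, and "the series" means these few. Any claim that something is new, unique, unknown or untested is made for them only; others in the source may bear on it.

Of the compounds shown here, two have been measured so far in a functional assay on A549 cells (Homo sapiens) for antiproliferative activity, read by MTT assay, with a stated time of 48 h; a higher number here means a weaker inhibitor, a lower number a stronger inhibitor. There, compound 1 (`Clc1ccc2[nH]c(-c3cn(-c4ccccc4)nc3-c3ccccc3)nc2c1`) gives 2370 nM and compound 2 (`COc1ccc(-c2nn(-c3ccccc3)cc2-c2nc3cc(F)ccc3[nH]2)cc1`) gives 1980 nM. These two values lie within the usual scatter of each other, so the numbers do not set compound 2 apart from compound 1.

The next structure is compound 3 (`COc1ccc(-c2nn(-c3ccccc3)cc2-c2nc3cc(Cl)ccc3[nH]2)cc1`), which differs from compound 2 in one place: chloro in place of fluoro on an aromatic carbon. That carbon belongs to a six-membered aromatic ring of carbon only, part of a fused or bridged system of two rings. Within the data shown here, no measured pair isolates this exchange, so the data give no direct guide to it. Compound 1 also carries chloro, and its value of 2370 nM offers the only indirect hint. No change beyond the scatter is therefore expected in this assay, in either direction, and the expected size is a 1.0-fold higher number from compound 2 to compound 3 (0.00 log units; within the scatter). Compound 3 is estimated to give about 2000 nM, within a range of 900 nM to 4400 nM.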

Compound 3, half-maximal inhibitory concentration: 3130 nM
Compound 3: middle estimate off by 1.6-fold (0.19 log units), on the low side; the measured number falls inside the stated range.
By their numbers in this assay, from the lowest: compounds 2, 1 and 3 (each within the scatter of the next).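

In this assay, the exchange of chloro in place of fluoro on the aromatic carbon of the shared core can now be read directly, and it gives a 1.6-fold higher number from compound 2 to compound 3 (0.20 log units; within the scatter) with the methoxy group held constant, so the numbers do not separate these two groups at this position. The second new pair adds a separate reading, with chloro held constant: methoxy in place of hydrogen on an aromatic carbon gives a 1.3-fold higher number from compound 1 to compound 3 (0.12 log units; within the scatter), so that exchange does not set the two compounds apart in this assay either. No measurement is available that bears on either step or offers an account of these numbers.

The compounds shown leave open whether a group of another kind at the chloro position, such as an amine, a carboxylic acid or a longer chain, would move the number beyond the scatter. They also leave open whether methoxy in place of hydrogen would read the same with fluoro on the shared core, since that exchange is seen here with chloro alone.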